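Pyridin-2-yl to phenyl on the thioether side chain

The compounds below may be only part of what the source reports. "The series", "measured", "known", "first", "only" and "open" are said of these compounds alone.

Measured so far in an assay on isolated protein for inhibition of retinal dehydrogenase 2 (Homo sapiens); a higher number here means a weaker inhibitor, a lower number a stronger inhibitor:
compound 1 `C#Cc1ccc(-n2c(SC(C)c3ccccc3)nc3c(cnn3C)c2=O)cc1`: 800 nM
compound 2 `CC(Sc1nc2nn(C3COC3)cc2c(=O)n1-c1ccccc1)c1ccccn1`: 21 nM
compound 3 `CC(Sc1nc2c(cnn2C)c(=O)n1-c1ccccc1)c1cccnc1`: 89 nM

Compound 2 gives the lowest number of the three in this assay. Its nearest neighbour is compound 3, whose value lies higher by a gap beyond the usual scatter; compound 1 lies furthest away, also well beyond the scatter. No two of these compounds differ in only one place, so no measured single step is available from them.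

Compound 4 `CC(Sc1nc2nn(C3COC3)cc2c(=O)n1-c1ccccc1)c1ccccc1` has not yet been measured in this assay. It follows from compound 2 by phenyl in place of pyridin-2-yl on a saturated chain carbon bound to a saturated chain carbon and a sulfur. For the measured compounds named here, the only measured compound that already carries the 1-phenylethyl group is compound 1, which gives 800 nM, but compound 1 differs from compound 2 elsewhere as well, so its value cannot be read as the effect of this change alone. The change removes the one hydrogen-bond acceptor counted in the leaving group and adds nothing in its place. A step towards a higher number, of moderate size and probably beyond the scatter, is expected. The expected step from compound 2 to compound 4 is a 3.1-fold higher number from compound 2 to compound 4 (0.49 log units; beyond the scatter). For compound 4 the estimate in this assay is 65 nM, with a range from 20 nM to 250 nM.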

Compound 4, half-maximal inhibitory concentration: 65 nM
Compound 4: middle estimate and measured number agree at the digits printed; the range from low to high includes it.
By their numbers in this assay, from the lowest: compound 2; then compounds 4 and 3 (each within the scatter of the next); then compound 1.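

For the compounds shown here, the first single-place step, phenyl in place of pyridin-2-yl on a saturated chain carbon bound to a saturated chain carbon and a sulfur, reads as a 3.1-fold higher number from compound 2 to compound 4 (0.49 log units; beyond the scatter) in this assay. This separates the change from the several differences between compound 1 and compound 2. At this position the step is modest but beyond the scatter, and it accompanies the removal of the one hydrogen-bond acceptor counted in the leaving group, while compound 4 still stands at 65 nM with the carbon-only ring in place. Nothing measured here accounts for the direction or size of this step.

With only this one replacement readable at the position, it remains open whether the placement of the ring nitrogen matters, since the pyridin-3-yl group of compound 3 has no counterpart shown on the core of compound 2. Also open, as far as these compounds go, is how an amine or a methoxy group on the phenyl ring of compound 4 would shift the number, and what the ethynyl group of compound 1 contributes on its own.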